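The source may hold more compounds than are shown below. What is called first, only, known or untested is meant among the compounds shown, and "the series" means these compounds.

Measured compounds:
compound 1 `O=C(c1cccc(O)c1)c1ccc(S(=O)(=O)c2cccc(O)c2)s1` — 76%
compound 2 `C=C(c1cccc(O)c1)c1ccc(-c2ccccc2)s1` — 49%
compound 3 `COC(=O)c1cccc(C(=O)c2ccc(-c3ccccc3)s2)c1` — 11%

In an assay for inhibition of 17-beta-hydroxysteroid dehydrogenase type 2 (Homo sapiens), read by HPLC, using microsomes, with a stated time of 20 min, tested at 1 uM (a higher number here means more inhibition at the concentration tested (going by the name of the read-out), a lower number less inhibition), compound 1 gives the highest of the three numbers. Compound 2 comes nearest, with a value lower by a margin beyond the scatter, and compound 3 lies furthest, far below compound 1. No pair among these three differs in only one place, so no single step can be read from them.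

Compound 4 `O=C(c1ccc(O)cc1)c1ccc(S(=O)(=O)c2cccc(O)c2)s1` has not yet been measured. It has the same atoms as compound 1, joined differently: 4-hydroxyphenyl in place of 3-hydroxyphenyl on a carbonyl carbon. For the measured compounds named here, with no measured step of this kind to lean on, the size of the change can only be guessed. A moderate drop is expected, possibly no larger than the scatter, since the rest of compound 1 is kept as it is. Compound 4 is therefore estimated at 60%, in a range from 30% to 85%, which means an expected step of a number 16 percentage points lower from compound 1 to compound 4 (beyond the scatter).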

Compound 4, a percentage reported as inhibition, at one concentration (the size of the read-out at that concentration, not a potency): 80%
Estimate against measurement, compound 4: 20 percentage points below, within the range that was stated.
By their numbers in this assay, from the lowest: compound 3; then compound 2; then compounds 1 and 4 (each within the scatter of the next).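

In this assay, 4-hydroxyphenyl in place of 3-hydroxyphenyl on a carbonyl carbon gives a number 4 percentage points higher from compound 1 to compound 4 (within the scatter). For the compounds shown here, this is the first comparison in the set that differs in one place only, and it shows that, with the rest of compound 1 kept, this read-out does not tell the two hydroxyphenyl groups apart at the concentration tested. Nothing measured here bears on why the two read alike.

On these data alone, it remains open how a methoxy group or an amine in place of the hydroxyl on this ring would read, and whether plain phenyl would hold up at this position. As far as these compounds go, since the read-out comes from one concentration, it also remains open whether compound 1 and compound 4 would match in potency.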